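A Cyclohexyl Amide Awaiting Its Keratinocyte Measurement

The compounds below may be only part of what the source reports. "The series", "measured", "known", "first", "only" and "open" are said of these compounds alone.

Compound 1, `COc1cc(-c2cc(C(=O)O)c3ccccc3n2)ccc1OCC(=O)Nc1ccc(C)cc1`, in an ADME assay on HaCaT cells (Homo sapiens) for inhibition (on this read-out lower numbers stand for stronger inhibition and higher numbers for weaker inhibition), gives > 300000 nM, which is a limit of the assay.
Compound 2, `COc1cc(-c2cc(C(=O)O)c3ccccc3n2)ccc1OCC(=O)NCc1cccnc1`, gives > 300000 nM, also a limit.
Compound 3, `COc1cc(-c2cc(C(=O)O)c3ccccc3n2)ccc1OCC(=O)NCc1cccs1`, gives > 300000 nM, again a limit.

Compound 3 therefore stands at the assay limit, as do the other two: the limit of > 300000 nM in this assay, at which 3 of the 3 values shown sit. Compound 4, `COc1cc(-c2cc(C(=O)O)c3ccccc3n2)ccc1OCC(=O)NC1CCCCC1`, differs from compound 3 in one place: cyclohexyl in place of (thiophen-2-yl)methyl on an amide-type nitrogen. The measured steps that bear on this change are a step that the two limits leave unreadable from compound 1 to compound 3 and a step that the two limits leave unreadable from compound 2 to compound 3; neither has a readable size, so no direction can be drawn from them. The step that the limit leaves unreadable from compound 3 to compound 4 is accordingly expected to be none beyond the scatter. Compound 4 is estimated at 400000 nM, within a range from 100000 nM to 1500000 nM, most likely again reported only as a limit.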

Compound 4, half-maximal inhibitory concentration in the HaCaT assay: > 300000 nM
Compound 4: only a limit was reported; the forecaster's own chance of this, stated with the estimate: 85%; the middle value does not contradict the limit.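

In the HaCaT assay compound 4 gives > 300000 nM, again a limit of the assay. Its steps from compound 1, compound 2 and compound 3 cannot be read. The compounds shown leave open whether any group on the amide-type nitrogen changes inhibition at all. In a physicochemical assay for lipophilicity, using the shake flask method, in phosphate buffer, measured as octanol-water partition, at pH 7.4 (on this read-out lower numbers stand for lower lipophilicity and higher numbers for higher lipophilicity), compound 3 gives 0 and compound 4 gives 0.8.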